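A few compounds are considered here, and "the series" means these few. Any claim that something is new, unique, unknown or untested is made for them only; others in the source may bear on it.

In an assay on isolated protein for inhibition of Rho-associated protein kinase 2 (Homo sapiens), read by scintillation counting, radiometric assay and 33P incorporation, with a stated time of 40 min, in the presence of a further agent that is not named here (on this read-out lower numbers stand for stronger inhibition and higher numbers for weaker inhibition), compound 3 `Cc1cc(C(=O)Nc2cccc(NC(=O)COc3ccc4c(=O)ccoc4c3)c2)ccc1C(F)(F)F` gives 43 nM, the highest of the three numbers, though the step of a 1.0-fold higher number from compound 2 to compound 3 (0.02 log units; within the scatter) shows it sits within the scatter of compound 2 `O=C(COc1ccc2c(=O)ccoc2c1)Nc1cccc(NC(=O)c2cccc([N+](=O)[O-])c2)c1`, which gives 41 nM. Compound 1 `O=C(COc1ccc2c(=O)ccoc2c1)Nc1cccc(NC(=O)c2ccc([N+](=O)[O-])cc2)c1` gives 15 nM, and the step of a 2.9-fold higher number from compound 1 to compound 3 (0.46 log units; beyond the scatter) is modest. Compound 4 `CC(C)(C)c1cc(C(=O)Nc2cccc(NC(=O)COc3ccc4c(=O)ccoc4c3)c2)no1` carries a group of 9 heavy atoms (7 carbon, 1 nitrogen, 1 oxygen; one five-membered aromatic ring with 2 hetero atoms) in place of a group of 11 heavy atoms (8 carbon, 3 fluorine; one six-membered aromatic ring of carbon only), on a carbonyl carbon. Neither measured step swaps a six-membered ring for a five-membered one on that carbonyl carbon, so they bear only loosely on this change; both exchanges seen at that position moved the number modestly or not beyond the scatter. A step of similar, uncertain size is therefore expected, a 1.2-fold higher number from compound 3 to compound 4 (0.07 log units; within the scatter), with no clear direction. Compound 4 is estimated at 50 nM, within a range from 15 nM to 160 nM.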

Compound 4, half-maximal inhibitory concentration: 5 nM
Compound 4: middle estimate off by 10-fold (1.00 log units), on the high side, and the stated range ends above it.
By their numbers in this assay, from the lowest: compound 4; then compound 1; then compounds 2 and 3 (each within the scatter of the next).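

Placing 5-(tert-butyl)-1,2-oxazol-3-yl on this carbonyl carbon gives an 8.6-fold lower number from compound 3 to compound 4 (0.93 log units; beyond the scatter), an 8.2-fold lower number from compound 2 to compound 4 (0.91 log units; beyond the scatter) and a 3.0-fold lower number from compound 1 to compound 4 (0.48 log units; beyond the scatter), each beyond the scatter. At this position, then, a five-membered aromatic ring with two hetero atoms can beat all three six-membered carbon rings shown, including the best of them in compound 1. No measurement here explains this gain. The compounds shown leave open whether the gain belongs to the ring or to the tert-butyl group. A methyl group on the same ring, or a phenyl ring carrying tert-butyl, would separate the two.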